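Adding a Second Chloro to Compound 2

The source may report more compounds than this note shows. Statements on the series, on what has been measured and on what is new or still open speak of the compounds shown alone.

Of the compounds shown here, two have been measured in a functional assay on MCF7 cells (Homo sapiens) for inhibition, read by sulforhodamine B assay, with a stated time of 48 h; on this read-out higher numbers stand for weaker inhibition of growth and lower numbers for stronger inhibition of growth. Compound 1 `N#C/C(=C\N1CCN(C(=O)c2ccco2)C1=S)C(=O)Nc1ccc(Cl)cc1` gives 21000 nM, and compound 2 `O=CN1CCN(c2ccc(Cl)cc2)C1=S` gives 2800 nM, the lower of the two numbers, with a gap to compound 1 that lies beyond the usual scatter. Compound 3 `O=CN1CCN(c2ccc(Cl)c(Cl)c2)C1=S` differs from compound 2 in one place: chloro in place of hydrogen on an aromatic carbon. For the measured compounds named here, no measured pair differing in a single place exists to guide this step, so in this assay a change from compound 2 to compound 3 of no more than the scatter is expected, in either direction. Compound 3 is therefore estimated at 2000 nM, within 600 nM to 6000 nM, an expected step of a 1.4-fold lower number from compound 2 to compound 3 (0.15 log units; within the scatter).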

Compound 3, concentration for 50% growth inhibition: 4600 nM
Compound 3: middle estimate off by 2.3-fold (0.36 log units), on the low side, within the range that was stated.
By their numbers in this assay, from the lowest: compounds 2 and 3 (each within the scatter of the next); then compound 1.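

In this assay, chloro in place of hydrogen on this aromatic carbon, ortho to a chloro group, gives a 1.6-fold higher number from compound 2 to compound 3 (0.22 log units; within the scatter) and so leaves compound 2 and compound 3 indistinguishable. This position therefore takes a second chloro without a difference beyond the scatter, something compound 1 could not show, as it differs from compound 2 in more than one place. Nothing available here offers an explanation for this result. Still open, on these data alone, is whether an amine, a methoxy group or a carboxylic acid on this same carbon would give a number beyond the scatter.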